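Nitrothiophene series: cyclohexyl in place of benzothiazolyl

The compounds below may be only part of what the source reports. "The series", "measured", "known", "first", "only" and "open" are said of these compounds alone.

Measured so far:
compound 1 `NC(=O)CN(Cc1ccc(Cl)cc1)Cc1ccc([N+](=O)[O-])s1` — 3000 nM
compound 2 `O=[N+]([O-])c1ccc(CN(Cc2ccc(Cl)cc2)Cc2nc3ccccc3s2)s1` — 4000 nM

In a functional assay on HEK293 cells for agonist activity at nuclear receptor subfamily 1 group D member 1 (Homo sapiens), read by a luciferase reporter, with a stated time of 24 h (a higher number here means that more compound is needed for the effect, a lower number that less compound is needed), compound 2 gives 4000 nM. Among the measured compounds shown here, the only other number is that of compound 1, and the two sit together: a 1.3-fold higher number from compound 1 to compound 2 (0.12 log units; within the scatter) lies within the scatter. Compound 3 `O=[N+]([O-])c1ccc(CN(Cc2ccc(Cl)cc2)CC2CCCCC2)s1` is not yet measured; it differs from compound 2 by cyclohexyl in place of 1,3-benzothiazol-2-yl on a saturated chain carbon bound to an amine nitrogen. For the measured compounds named here, the single measured step, a 1.3-fold higher number from compound 1 to compound 2 (0.12 log units; within the scatter), concerns the same saturated chain carbon bound to an amine nitrogen and stayed within the scatter, but no measured pair tests a non-aromatic ring there. The step to compound 3 is therefore expected to stay near the scatter, if anything toward a higher number. Compound 3 is estimated at 5000 nM, range 1500 nM to 20000 nM. This estimate expects a 1.3-fold higher number from compound 2 to compound 3 (0.10 log units; within the scatter).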

Compound 3, half-maximal effective concentration: 7400 nM
Compound 3: the middle estimate sits 1.5-fold (0.17 log units) below what was measured, and the stated range covers the measured number.
By their numbers in this assay, from the lowest: compounds 1, 2 and 3 (each within the scatter of the next, the first and the last beyond it).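

In this assay a non-aromatic ring of carbon only is accepted on the saturated chain carbon bound to an amine nitrogen: cyclohexyl in place of 1,3-benzothiazol-2-yl gives a 1.9-fold higher number from compound 2 to compound 3 (0.27 log units; within the scatter), so the aromatic rings and hetero atoms are not needed for a reading in this range. Cyclohexyl in place of carbamoyl gives a 2.5-fold higher number from compound 1 to compound 3 (0.39 log units; beyond the scatter), the first step at this position beyond the scatter, though modest. No evidence on the origin of this step is available. Open, on these data alone, is whether a carboxylic acid, a basic amine or a longer chain on this carbon would leave this narrow band of numbers.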